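Removing the aryl ether from a triazole sulfonamide

This account rests on a few compounds, and the source may have more. Where it says the series, first, only, none or still open, it means among the compounds named here.

Compound 1 `O=S(=O)(c1ccc(-n2cc(COc3ccccc3)nn2)cc1)N1CCc2ccccc2C1`: in a functional assay on MOLT-3 cells (Homo sapiens) for cytotoxicity, read by MTT assay, with a stated time of 48 h (a lower number here means a stronger inhibitor, a higher number a weaker inhibitor), compound 1 gives > 50 ug/mL, which is a limit of the assay.
Compound 2 `COc1cc2c(cc1OC)CN(S(=O)(=O)c1ccc(-n3cc(COc4ccc(C)cc4)nn3)cc1)CC2`: in this assay compound 2 gives > 50 ug/mL, also a limit.
Compound 3 `O=S(=O)(c1ccc(-n2cc(COc3ccc4ccccc4c3)nn2)cc1)N1CCc2ccccc2C1`: in this assay compound 3 gives > 50 ug/mL, again a limit.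

Compound 2 therefore stands at the limit of > 50 ug/mL in this assay, at which 3 of the 3 values shown sit; no number separates it from the other two. Within the data shown here, the only step between measured compounds, a step that the two limits leave unreadable from compound 1 to compound 3, yields no readable size, since both of its ends are limits.

Compound 4 `COc1cc2c(cc1OC)CN(S(=O)(=O)c1ccc(-n3cc(CO)nn3)cc1)CC2` differs from compound 2 in one place: hydrogen in place of 4-methylphenyl on an oxygen on a saturated carbon. Among the measured compounds shown here, no measured step bears on this change, and every known value sits at the limit, so nothing points to a gain in potency. The step that the limit leaves unreadable from compound 2 to compound 4 is expected to stay within the scatter. Compound 4 is estimated at 60 ug/mL, with a range from 30 ug/mL to 120 ug/mL, and most likely it is again reported only as a limit.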

Compound 4, half-maximal inhibitory concentration: > 50 ug/mL
Compound 4 ended at the assay's limit; the forecaster's own chance of this, stated with the estimate: 85%; the middle value does not contradict the limit.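

Compound 2 and compound 4 both end at a limit, so no size can be read for the change between them: the limit of > 50 ug/mL in this assay, at which 4 of the 4 values shown sit.

The compounds shown leave open which change, if any, would give a readable value in this assay.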